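The source may hold more compounds than are shown below. What is called first, only, known or untested is meant among the compounds shown, and "the series" means these compounds.

Measured so far:
compound 1, `CC(C)(C)c1cn(C[C@H](O)[C@H]2OC(=O)C(OCc3ccccc3)=C2OCc2ccccc2)nn1`: 29200 nM
compound 2, `COc1ccc(-c2cn(C/C=C3\OC(=O)C(OCc4ccccc4)=C3OCc3ccccc3)nn2)cc1`: > 100000 nM (a limit of the assay)
compound 3, `Cc1ccc(-c2cn(C/C=C3\OC(=O)C(OCc4ccccc4)=C3OCc3ccccc3)nn2)cc1`: > 100000 nM (a limit of the assay)

Among the measured compounds shown here, in a functional assay on HepG2 cells (Homo sapiens) for antiproliferative activity, read by MTT assay, with a stated time of 72 h (a lower number here means a stronger inhibitor, a higher number a weaker inhibitor), compound 1 gives 29200 nM, the only number among the three values shown. Compound 2 sits at a limit of the assay, > 100000 nM. Compound 3 likewise sits at a limit, > 100000 nM. The step that the two limits leave unreadable from compound 2 to compound 3 is therefore of unreadable size, because the limit of > 100000 nM in this assay, at which 2 of the 3 values shown sit, hides it. Compound 4, `O=C1O[C@H]([C@@H](O)Cn2cc(C3CC3)nn2)C(OCc2ccccc2)=C1OCc1ccccc1`, differs from compound 1 by cyclopropyl in place of tert-butyl on an aromatic carbon. For the measured compounds named here, the only measured step that touches the group on the triazole is unreadable, so no step of known size bears on this change. Compound 4 is therefore expected to stay close to compound 1, with a step of a 1.1-fold higher number from compound 1 to compound 4 (0.04 log units; within the scatter) that lies within the scatter. The estimate for compound 4 is 32000 nM, between 12000 nM and 85000 nM.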

Compound 4, half-maximal inhibitory concentration: 38100 nM
Beside the measured number, compound 4's estimate is 1.2-fold (0.08 log units) below it; low and high end bracket the measured number.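

In this assay the group on the triazole now has its first readable step (a 1.3-fold higher number from compound 1 to compound 4 (0.12 log units; within the scatter)), where the earlier pair gave none. Cyclopropyl, which brings a three-membered ring, can thus stand in place of tert-butyl at this aromatic carbon with no change that the scatter would let one read. Nothing measured here gives a reason for this result.

From the compounds shown here alone, whether an amine or a carboxylic acid on this same aromatic carbon would shift the value stays open. So does the effect of a longer chain there.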